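Three aryl amides, one shared core, a new aryl

This account rests on a few compounds, and the source may have more. Where it says the series, first, only, none or still open, it means among the compounds named here.

Compound 1, `O=C(COc1ccc(/C=C2\SC(=O)NC2=O)cc1)Nc1ccc([N+](=O)[O-])cc1`, is one of three closely related compounds that share the same core and differ only in the aryl group carried on the amide-type nitrogen. In a functional assay on MCF7 cells (Homo sapiens) for inhibition (on this read-out higher numbers stand for weaker inhibition of growth and lower numbers for stronger inhibition of growth), compound 1 gives 72500 nM, the highest of the three numbers, though every gap to the others lies within the scatter. Compound 2, `O=C(COc1ccc(/C=C2\SC(=O)NC2=O)cc1)Nc1ccc(Cl)cc1`, gives 51100 nM in this assay, and compound 3, `Cc1ccc(NC(=O)COc2ccc(/C=C3\SC(=O)NC3=O)cc2)cc1Cl`, gives 61800 nM.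

Compound 4, `O=C(COc1ccc(/C=C2\SC(=O)NC2=O)cc1)Nc1c(F)cc(Br)cc1F`, has not yet been measured. It differs from compound 1 in one place: 4-bromo-2,6-difluorophenyl in place of 4-nitrophenyl on an amide-type nitrogen.

The measured steps that bear on this change all swap one aryl group for another on the same amide-type nitrogen. The step of a 1.4-fold lower number from compound 1 to compound 2 (0.15 log units; within the scatter) and the step of a 1.2-fold lower number from compound 1 to compound 3 (0.07 log units; within the scatter) both stayed within the scatter, as did the step of a 1.2-fold higher number from compound 2 to compound 3 (0.08 log units; within the scatter). Three different aryl groups therefore gave much the same number in this assay. On that basis the step of a 1.3-fold lower number from compound 1 to compound 4 (0.12 log units; within the scatter) is expected to be small as well, and the number for compound 4 is estimated at 55000 nM, with a range from 25000 nM to 120000 nM.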

Compound 4, concentration for 50% growth inhibition: 57300 nM
Compound 4: the middle estimate sits 1.0-fold (0.02 log units) below what was measured; measured number inside the range.
By their numbers in this assay, from the lowest: compounds 2, 4, 3 and 1 (each within the scatter of the next).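

The change on the amide-type nitrogen is a substantial one: 4-bromo-2,6-difluorophenyl carries two fluorines and a bromine and has no hydrogen-bond acceptors, whereas 4-nitrophenyl has two, yet in this assay the swap gives a 1.3-fold lower number from compound 1 to compound 4 (0.10 log units; within the scatter) and nothing more. The comparisons with the other two aryl groups read the same way, with a 1.1-fold lower number from compound 3 to compound 4 (0.03 log units; within the scatter) and a 1.1-fold higher number from compound 2 to compound 4 (0.05 log units; within the scatter) on record for this position. This new aryl group therefore extends the flat picture from three compounds to four, and none of the four goes against it: among these aryl groups, the number in this assay does not respond to the change of substituents on the ring.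

Going by these compounds, all four compounds carry a substituted phenyl ring on this nitrogen, so it remains open whether a ring bearing an amine or a carboxylic acid, or a saturated alkyl chain in place of the ring, would give a clearly different number. No measurement at hand explains why these aryl groups give such similar numbers.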